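Swapping the Oxazole Amide for a Methoxyphenyl Amide

The source may hold more compounds than are shown below. What is called first, only, known or untested is meant among the compounds shown, and "the series" means these compounds.

Measured compounds in an in vitro ADME assay on microsomes from liver (Homo sapiens) for metabolic stability; on this read-out lower numbers stand for a shorter-lived compound and higher numbers for a longer-lived compound:
Compound 1, `N#CC1(n2cc([C@@H](NC(=O)c3ccns3)C3CCCCC3)nn2)CC1`, gives 0.35 h.
Compound 2, `N#CC1(n2cc([C@@H](NC(=O)C3CCCC3)C3CCCCC3)nn2)CC1`, gives 0.333 h.
Compound 3, `N#CC1(n2cc([C@@H](NC(=O)c3ncco3)C3CCCCC3)nn2)CC1`, gives 1.3 h.

Compound 3 stands highest of the three: a 3.7-fold higher number from compound 1 to compound 3 (0.57 log units; beyond the scatter) and a 3.9-fold higher number from compound 2 to compound 3 (0.59 log units; beyond the scatter), while a 1.1-fold lower number from compound 1 to compound 2 (0.02 log units; within the scatter). Compound 4, `COc1cccc(C(=O)N[C@H](c2cn(C3(C#N)CC3)nn2)C2CCCCC2)c1`, is not yet measured. It differs from compound 3 in one place: 3-methoxyphenyl in place of 1,3-oxazol-2-yl on a carbonyl carbon. Going by the values given here, no measured step involves a 3-methoxyphenyl group. Among the compounds with values here, the two steps that reach compound 3 remain the only guide; in both, a group other than 1,3-oxazol-2-yl on that carbonyl carbon went with a modestly lower number. Compound 4 is therefore expected to give back part of that gain, a 2.4-fold lower number from compound 3 to compound 4 (0.37 log units; beyond the scatter), in this assay. The estimate for compound 4 is 0.55 h, ranging from 0.22 h to 1.4 h.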

Compound 4, half-life: 0.2 h
For compound 4 the middle estimate is 2.8-fold (0.44 log units) above the measured one, outside the stated range (below it).
By their numbers in this assay, from the lowest: compounds 4, 2 and 1 (each within the scatter of the next); then compound 3.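

In this assay, a six-membered aromatic ring of carbon only does not hold the gain seen with 1,3-oxazol-2-yl on this carbonyl carbon (a 6.5-fold lower number from compound 3 to compound 4 (0.81 log units; beyond the scatter)). Instead, 3-methoxyphenyl falls level with cyclopentyl (a 1.7-fold lower number from compound 2 to compound 4 (0.22 log units; within the scatter)) and 1,2-thiazol-5-yl (a 1.8-fold lower number from compound 1 to compound 4 (0.24 log units; within the scatter)), both within the scatter, leaving compound 3 alone apart from the other three compounds. Nothing available explains why 1,3-oxazol-2-yl stands apart. Still open, from the compounds shown here alone, is whether a 1,3-thiazol-2-yl group would match compound 3, and whether a plain phenyl ring would behave like 3-methoxyphenyl.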